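This account rests on a few compounds, and the source may have more. Where it says the series, first, only, none or still open, it means among the compounds named here.

Measured compounds:
compound 1, `CN(C)c1ccc(-c2nc(NN)n(C)c(=O)c2C#N)cc1`: 66 ug/mL
compound 2, `CSc1nc(-c2ccccc2O)c(C#N)c(=O)n1C`: 39 ug/mL
compound 3, `Cn1c(NN)nc(-c2ccccc2O)c(C#N)c1=O`: 30 ug/mL

All three were run in a functional assay, with a stated time of 10 min; a higher number here means a weaker inhibitor, a lower number a stronger inhibitor. Compound 3 gives 30 ug/mL and compound 2 gives 39 ug/mL; the step between them, a 1.3-fold higher number from compound 3 to compound 2 (0.11 log units; within the scatter), comes from one change, (methylsulfanyl in place of aminoamino on an aromatic carbon). Compound 1 gives 66 ug/mL, a number beyond the scatter from that of compound 3 and within the scatter of that of compound 2. The difference between the core of compound 1 and the core of compound 3 is not broken down here.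

Compound 4, `CSc1nc(-c2ccc(N(C)C)cc2)c(C#N)c(=O)n1C`, has not yet been measured. It arises from compound 1 by methylsulfanyl in place of aminoamino on an aromatic carbon, the same kind of change as that from compound 3 to compound 2; the surroundings differ only in that the carbon is meta to a group of 9 heavy atoms rather than meta to a group of 7 heavy atoms. A step of about a 1.3-fold higher number from compound 1 to compound 4 (0.11 log units; within the scatter) is expected, resting on the measured 1.3-fold higher number from compound 3 to compound 2 (0.11 log units; within the scatter) beside it. Compound 4 is therefore expected to give 85 ug/mL in this assay, most likely between 40 ug/mL and 170 ug/mL.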

Compound 4, half-maximal inhibitory concentration: 84 ug/mL
The estimate for compound 4 lay 1.0-fold (0.01 log units) above the measured number; the measured number falls inside the stated range.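

In this assay, putting methylsulfanyl in place of aminoamino on the core of compound 1 gives a 1.3-fold higher number from compound 1 to compound 4 (0.10 log units; within the scatter) and so stays within the scatter on this core. Set beside the earlier step, the change carries from one core to the other with no difference that can be told apart: the same change on two cores in this assay, a 1.3-fold higher number (0.11 log units; within the scatter) from compound 3 to compound 2 and a 1.3-fold higher number (0.10 log units; within the scatter) from compound 1 to compound 4, 1.0-fold (0.01 log units) apart, within the scatter of two such steps. This shows agreement between two small steps on two cores in one assay only; it neither establishes a real effect of the change nor shows that the same step would be found on any further core in the series.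

The compounds shown leave open what other groups on this aromatic carbon would give, such as a simple amine, a morpholine or a longer alkylsulfanyl chain. Also open, on these data alone, is whether the step between aminoamino and methylsulfanyl would stay the same on a core carrying a carboxylic acid in place of the cyano group.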